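The source may hold more compounds than are shown below. What is called first, only, known or untested is meant among the compounds shown, and "the series" means these compounds.

In a functional assay on the whole organism (strain Sprague-Dawley) for inhibition, with Rattus norvegicus as the target, with a stated time of 10 min (a lower number here means that less compound is needed, a higher number that more compound is needed for the effect), compound 1, `O=C(O)c1cnc(-c2ccccc2Cl)[nH]c1=O`, gives 5 mg/kg, the lowest of the two numbers shown. Compound 3, `Nc1ccccc1-c1ncc(C(=O)O)c(=O)[nH]1`, gives 50 mg/kg. Compound 2, `O=C(O)c1cnc(-c2ccccc2[N+](=O)[O-])[nH]c1=O`, reaches only the limit of > 50 mg/kg in this assay, so no number is known for it. The step of a 10-fold higher number from compound 1 to compound 3 (1.00 log units; beyond the scatter) and the step of an at least 10-fold higher number from compound 1 to compound 2 (1.00 log units; beyond the scatter) show that both replacements of the chloro raised the number. Compound 4, `CCCOc1ccccc1-c1ncc(C(=O)O)c(=O)[nH]1`, has not yet been measured; it differs from compound 1 in this way: propoxy in place of chloro on an aromatic carbon. The two measured steps each exchange the chloro on the same aromatic carbon for another group, and each gave a higher number, so a higher number is expected for compound 4 as well, though propoxy is unlike nitro or amino and the size stays uncertain. The expected step is a 3.0-fold higher number from compound 1 to compound 4 (0.48 log units; beyond the scatter). For compound 4 the estimate in this assay is 15 mg/kg, with a range from 5 mg/kg to 50 mg/kg.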

Compound 4, dose for 50% inhibition: 0.9 mg/kg
The estimate for compound 4 lay 17-fold (1.22 log units) above the measured number; measured number below the stated range.
By their numbers in this assay, from the lowest: compound 4; then compound 1; then compound 3.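

Propoxy on this aromatic carbon, ortho to a large group, is the first replacement of chloro shown that lowers the number, with a 5.6-fold lower number from compound 1 to compound 4 (0.74 log units; beyond the scatter) in this assay, so among these compounds a group with more heavy atoms than chloro is accepted here. The contrast with the other two groups is wider, with a 56-fold lower number from compound 3 to compound 4 (1.74 log units; beyond the scatter) and an at least 55-fold lower number from compound 2 to compound 4 (1.74 log units; beyond the scatter). The second of these steps rests on a limit for compound 2, not on a number: the limit of > 50 mg/kg in this assay, at which 1 of the 4 values shown sits.

The compounds shown do not separate the part played by the oxygen from that of the chain, which a butyl group would address. Nor do they show whether methoxy or a longer chain such as butoxy would lower the number further or raise it again.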